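The source may hold more compounds than are shown below. What is called first, only, known or untested is meant among the compounds shown, and "the series" means these compounds.

Compound 3, `CC(O)Cn1c([N+](=O)[O-])cnc1/C=C/c1ccccc1F`, is one of three analogues examined in an ADME assay on cells (Macrophage, Homo sapiens) for cytotoxicity, read by MTT assay, with a stated time of 24 h (a lower number here means that less compound is tolerated, a higher number that more compound is tolerated), where it gives 1410 nM. The two companions share the core of compound 3 and differ only in the aryl group carried on the double-bonded chain carbon. Compound 2, `CC(O)Cn1c([N+](=O)[O-])cnc1/C=C/c1ccc(F)cc1`, gives 420 nM in this assay, and compound 1, `CC(O)Cn1c([N+](=O)[O-])cnc1/C=C/c1ccc(Cl)cc1`, gives 980 nM. Compound 3 stands at the highest number of the three, but its step from compound 1 is a 1.4-fold higher number from compound 1 to compound 3 (0.16 log units; within the scatter), whereas the step from compound 2 to compound 3 is a 3.4-fold higher number from compound 2 to compound 3 (0.53 log units; beyond the scatter); the cores of compound 2 and compound 3 differ as 2-fluorophenyl in place of 4-fluorophenyl on a double-bonded chain carbon bound to a double-bonded chain carbon.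

Compound 4, `CC(O)Cn1c([N+](=O)[O-])cnc1/C=C/c1ccccc1Cl`, is not yet measured. It differs from compound 3 by chloro in place of fluoro on an aromatic carbon. The same kind of change has been seen once already, between compound 2 and compound 1, as chloro in place of fluoro on an aromatic carbon, where it produced a 2.3-fold higher number from compound 2 to compound 1 (0.37 log units; beyond the scatter). The two places are not identical: in the measured pair the chloro sits para to a large group, while in compound 4 it sits ortho to a large group, so the earlier step is a guide rather than a repeat.

Resting on the step from compound 2 to compound 1 of a 2.3-fold higher number from compound 2 to compound 1 (0.37 log units; beyond the scatter), compound 4 is expected to show a similar step, estimated as a 1.8-fold higher number from compound 3 to compound 4 (0.27 log units; within the scatter), in this assay. Compound 4 is therefore estimated at 2600 nM, with a likely span from 1200 nM to 5500 nM.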

Compound 4, half-maximal cytotoxic concentration: 480 nM
Estimate against measurement, compound 4: 5.4-fold (0.73 log units) above, outside the stated range (below it).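

The new step, a 2.9-fold lower number from compound 3 to compound 4 (0.47 log units; beyond the scatter), shows that chloro in place of fluoro cannot be carried unchanged from the 4-fluorophenyl compound to the 2-fluorophenyl compound in this assay, since the same change runs in opposite directions on the two cores: the same change on two cores in this assay, a 2.3-fold higher number (0.37 log units; beyond the scatter) from compound 2 to compound 1 and a 2.9-fold lower number (0.47 log units; beyond the scatter) from compound 3 to compound 4, 6.9-fold (0.84 log units) apart, beyond the scatter of two such steps

The remaining steps place compound 4 among its companions, with a 1.1-fold higher number from compound 2 to compound 4 (0.06 log units; within the scatter) and a 2.0-fold lower number from compound 1 to compound 4 (0.31 log units; beyond the scatter), so the 2-chlorophenyl compound stands level with the 4-fluorophenyl compound and apart from the 4-chlorophenyl compound. For the compounds shown here, this rests on only two matched pairs, so it shows that the outcome of this exchange depends on the core that carries it, but it does not show why the direction reverses, nor whether a reversal would recur for other exchanges.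

The compounds shown leave open how a bromo, methoxy or trifluoromethyl group would behave at these same places on the aromatic ring, and whether any of them would follow the step seen with the 4-substituted pair or the one seen with the 2-substituted pair. They also leave open whether the reversal would survive if the hydroxyl-bearing chain on the shared core gave way to a longer chain or an amine.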